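The compounds below may be only part of what the source reports. "The series", "measured", "known", "first", "only" and "open" are said of these compounds alone.

Measured in a physicochemical assay, read by spectrophotometry; on this read-out lower numbers stand for stronger inhibition and higher numbers for weaker inhibition:
- compound 1 `CN(C)c1ccc(/C=C/C(=O)/C(CNc2ccccc2)=C(O)/C=C/c2ccc(N(C)C)cc2)cc1` gives 79.1 ug/mL
- compound 2 `COc1cc(C=C(C(=O)/C=C/c2ccc(N(C)C)cc2)C(=O)/C=C/c2ccc(N(C)C)cc2)ccc1O` gives 75.4 ug/mL
- compound 3 `COc1ccc(-n2nc(/C=C/c3ccc(N(C)C)cc3)cc2/C=C/c2ccc(N(C)C)cc2)cc1` gives 88.1 ug/mL

Compound 3 lies within the scatter of both compound 1 and compound 2, so no order can be read among the three values. Compound 4 `CN(C)c1ccc(/C=C/c2cc(/C=C/c3ccc(N(C)C)cc3)[nH]n2)cc1` differs from compound 3 by hydrogen in place of 4-methoxyphenyl on an aromatic nitrogen, with hydrogen in place of 4-methoxyphenyl on an aromatic nitrogen. Going by the values given here, no measured pair isolates this change. However, three differing structures share one band in this assay, and compound 3 at 88.1 ug/mL is part of it. No step beyond the scatter is therefore expected, and no direction is predicted. The expected step of a 1.1-fold lower number from compound 3 to compound 4 (0.04 log units; within the scatter) stays within the scatter. For compound 4 the estimated value is 80 ug/mL, with an expected range of 45 ug/mL to 140 ug/mL.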

Compound 4, half-maximal inhibitory concentration: 46.1 ug/mL
Estimate against measurement, compound 4: 1.7-fold (0.24 log units) above, within the range that was stated.
By their numbers in this assay, from the lowest: compounds 4, 2, 1 and 3 (each within the scatter of the next).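

Hydrogen in place of 4-methoxyphenyl on an aromatic nitrogen is the first change in the series that can be read in one place, and in this assay it stays within the scatter (a 1.9-fold lower number from compound 3 to compound 4 (0.28 log units; within the scatter)). This position thus carries either 4-methoxyphenyl or hydrogen with no step beyond the scatter, so the aromatic ring there is not required to hold the value in this band. No measured property bears on this result. Open, from the compounds shown here alone, is how a methyl group or a carboxylic acid chain on this nitrogen would read.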